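Ester variation at the cinnamate terminus

A few compounds are considered here, and "the series" means these few. Any claim that something is new, unique, unknown or untested is made for them only; others in the source may bear on it.

Compound 3 `CCOc1cc(NC(=O)C2(NC(=O)c3ccc4c(C5CCCC5)c(-c5ncc(Cl)cn5)n(C)c4c3)CCC2)ccc1/C=C/C(=O)OCc1ccccc1` is the starting point in an ADME assay (liver) for pharmacokinetics, with Liver microsome (Homo sapiens) as the target, using microsomes; on this read-out lower numbers stand for a shorter-lived compound and higher numbers for a longer-lived compound. In this assay compound 3 gives > 5 h, which is a limit of the assay and not a number. Compound 1 `CCCOC(=O)/C=C/c1ccc(NC(=O)C2(NC(=O)c3ccc4c(C5CCCC5)c(-c5ncc(Cl)cn5)n(C)c4c3)CCC2)cc1OCC` gives > 5 h, likewise a limit. Compound 2 `CCOc1cc(NC(=O)C2(NC(=O)c3ccc4c(C5CCCC5)c(-c5ncc(Cl)cn5)n(C)c4c3)CCC2)ccc1/C=C/C(=O)OCC(Cl)(Cl)Cl` gives > 5 h, also a limit. Thus (the limit of > 5 h in this assay, at which 3 of the 3 values shown sit), and the steps a step that the two limits leave unreadable from compound 1 to compound 2, a step that the two limits leave unreadable from compound 1 to compound 3 and a step that the two limits leave unreadable from compound 2 to compound 3 cannot be sized. Compound 4 `CCOc1cc(NC(=O)C2(NC(=O)c3ccc4c(C5CCCC5)c(-c5ncc(Cl)cn5)n(C)c4c3)CCC2)ccc1/C=C/C(=O)OCCOc1ccccc1` differs from compound 3 by phenoxymethyl in place of phenyl on a saturated chain carbon bound to an oxygen next to a carbonyl group. All three measured steps change this same position, yet none gives a readable size, so no direction can be drawn from them. The step that the limit leaves unreadable from compound 3 to compound 4 is therefore expected to stay at the limit. Compound 4 is estimated at 6 h, within 2.5 h to 15 h.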

Compound 4, half-life: > 5 h
Compound 4 gave a limit, no number (the forecaster's own chance of this, stated with the estimate: 70%); the middle value does not contradict the limit.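

In this assay compound 4 gives > 5 h, a limit and not a number, so its steps from compound 1, compound 2 and compound 3 cannot be read: the limit of > 5 h in this assay, at which 4 of the 4 values shown sit.

Going by these compounds, whether these four esters differ at all in half-life stays open.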